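Fluoro to aminomethyl on the aryl of compound 2

The compounds below may be only part of what the source reports. "The series", "measured", "known", "first", "only" and "open" are said of these compounds alone.

Measured compounds:
compound 1 `Cn1cc(-c2ccc(CN3CCC(O)(Cn4cnc5c(-c6ccc(CN)cc6)n(C)nc5c4=O)CC3)c(Cl)c2)cn1` — 291 nM
compound 2 `Cn1nc2c(=O)n(CC3(O)CCN(Cc4ccc(-c5ccco5)cc4Cl)CC3)cnc2c1-c1ccc(F)cc1` — 64.5 nM

Of the compounds shown here, two have been tested in an assay on isolated protein for inhibition of ubiquitin carboxyl-terminal hydrolase 7 (Homo sapiens), with stated times of 30 min and 2 h; on this read-out higher numbers stand for weaker inhibition and lower numbers for stronger inhibition. Compound 2 gives 64.5 nM, the lowest of the two numbers; compound 1 gives 291 nM, a gap that lies beyond the scatter. Among the compounds with values here, these two compounds differ in more than one place, so no single step between them is counted.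

Compound 3 `Cn1nc2c(=O)n(CC3(O)CCN(Cc4ccc(-c5ccco5)cc4Cl)CC3)cnc2c1-c1ccc(CN)cc1` has not yet been measured in this assay. It departs from compound 2 in one place: aminomethyl in place of fluoro on an aromatic carbon. Compound 1 also carries the aminomethyl group on the same ring, together with other changes, and its number is higher than that of compound 2. On that slim basis a moderate weakening is expected, a 2.0-fold higher number from compound 2 to compound 3 (0.30 log units; within the scatter), while a result within the scatter cannot be ruled out. Compound 3 is estimated at 130 nM, with a likely range from 50 nM to 400 nM.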

Compound 3, half-maximal inhibitory concentration: 18.1 nM
Compound 3: middle estimate off by 7.2-fold (0.86 log units), on the high side, and the stated range ends above it.
By their numbers in this assay, from the lowest: compound 3; then compound 2; then compound 1.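

In this assay, the change from 4-fluorophenyl to 4-(aminomethyl)phenyl gives a 3.6-fold lower number from compound 2 to compound 3 (0.55 log units; beyond the scatter) and so shows that aminomethyl on this aromatic carbon, para to a large group, goes with stronger inhibition than fluoro in this series. The higher number of compound 1 therefore did not speak against aminomethyl: with aminomethyl held in place, furan-2-yl in place of 1-methyl-1H-pyrazol-4-yl gives a 16-fold lower number from compound 1 to compound 3 (1.21 log units; beyond the scatter) and marks that other position as the larger source of the gap. No supporting measurement is available to explain either step. The compounds shown leave open whether a primary amine set directly on the ring, a longer aminoethyl chain or a hydroxymethyl group would match aminomethyl here. They also leave open whether furan-2-yl would keep its advantage over 1-methyl-1H-pyrazol-4-yl with fluoro on the aryl ring.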